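This account rests on a few compounds, and the source may have more. Where it says the series, first, only, none or still open, it means among the compounds named here.

Compound 2 `COc1ccc(-c2csc(N)c2C(=O)OCc2ccncc2)cc1OC` stands lowest of the two numbers measured in an assay on isolated protein for inhibition of protein kinase C zeta type (Homo sapiens), with stated times of 1 h and 2.5 min, tested at 30 uM; on this read-out lower numbers stand for less inhibition and higher numbers for more inhibition at the one concentration tested (going by the name of the read-out): compound 2 gives 53%, while compound 1 `COc1ccc(-c2csc(N)c2C(=O)OCc2ccccc2)cc1OC` gives 100%. Going by the values given here, the single measured step, a number 47 percentage points lower from compound 1 to compound 2 (beyond the scatter), was large and altered the group hanging from the carbonyl carbon, the same position that compound 3 `CCNC(=O)c1c(-c2ccc(OC)c(OC)c2)csc1N` changes again: ethylamino in place of (pyridin-4-yl)methoxy on a carbonyl carbon. That step bears on this change only loosely, as here a group with no ring enters. A further drop beyond the scatter is nonetheless expected, a number 18 percentage points lower from compound 2 to compound 3 (beyond the scatter), with wide uncertainty. Compound 3 is estimated at 35%, within 5% to 70%.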

Compound 3, a percentage reported as inhibition, at one concentration (the size of the read-out at that concentration, not a potency): 50%
Estimate against measurement, compound 3: 15 percentage points below; low and high end bracket the measured number.
By their numbers in this assay, from the lowest: compounds 3 and 2 (each within the scatter of the next); then compound 1.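

Ethylamino in place of (pyridin-4-yl)methoxy on a carbonyl carbon (a number 3 percentage points lower from compound 2 to compound 3 (within the scatter)) shows that in this assay this position can lose the ring with no change beyond the scatter. Ethylamino in place of benzyloxy (a number 50 percentage points lower from compound 1 to compound 3 (beyond the scatter)) is a large step, so among these three compounds only the benzyloxy of compound 1 stands apart. Nothing available explains either step. On these data alone, whether benzylamino on the carbonyl carbon would match benzyloxy remains open. As far as these compounds go, how a longer chain or a carboxylic acid would read at this place is also open.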